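The compounds below may be only part of what the source reports. "The series", "measured", "known", "first", "only" and "open" are said of these compounds alone.

Measured so far in a functional assay on HCT-116 cells (Homo sapiens) for antiproliferative activity, read by MTT assay, with a stated time of 48 h; on this read-out lower numbers stand for stronger inhibition of growth and higher numbers for weaker inhibition of growth:

Compound 1 `Cc1ccc(-c2cnc(N(Cc3ccccc3)Cc3ccc(C(=O)NO)cc3)s2)cc1`: 48800 nM
Compound 2 `Cc1ccc(-c2cnc(N(CCCCOc3ccccc3)Cc3ccc(C(=O)NO)cc3)s2)cc1`: 680 nM
Compound 3 `CCCCN(Cc1ccc(C(=O)NO)cc1)c1ncc(-c2ccc(C)cc2)s1`: 8780 nM

Compound 3 stands in the middle of this small set, with a lower number than compound 1 and a higher number than compound 2, and both gaps are beyond the scatter. Compound 4 `CCCN(Cc1ccc(C(=O)NO)cc1)c1ncc(-c2ccc(C)cc2)s1` differs from it only in the chain, which goes from butyl to propyl: hydrogen in place of methyl on a saturated chain carbon, three bonds along the chain from a nitrogen on an aromatic ring. In words, this is hydrogen in place of methyl on a saturated chain carbon, three bonds along the chain from a nitrogen on an aromatic ring.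

For the measured compounds named here, no measured pair isolates a change this small. The closest guide is hydrogen in place of phenoxy on the same chain, which gave a 13-fold higher number from compound 2 to compound 3 (1.11 log units; beyond the scatter). Propyl in place of phenyl gave a 5.6-fold lower number from compound 1 to compound 3 (0.74 log units; beyond the scatter), so the values do move with what this chain carries. Three compounds are too few to show a trend with chain length. Losing a methyl is a far smaller change than losing phenoxy, so only a small step towards a higher number is expected in this assay, and it may stay within the scatter. The expected step is a 1.4-fold higher number from compound 3 to compound 4 (0.14 log units; within the scatter). For compound 4 the estimated value is 12000 nM, with an expected range from 4500 nM to 30000 nM.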

Compound 4, concentration for 50% growth inhibition: 5800 nM
For compound 4 the middle estimate is 2.1-fold (0.32 log units) above the measured one; low and high end bracket the measured number.
By their numbers in this assay, from the lowest: compound 2; then compounds 4 and 3 (each within the scatter of the next); then compound 1.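

In this assay, hydrogen in place of methyl, three bonds along the chain from the nitrogen on the aromatic ring, gives a 1.5-fold lower number from compound 3 to compound 4 (0.18 log units; within the scatter) and so separates butyl from propyl by no more than repeat measurements would. Hydrogen in place of phenoxymethyl at that same place gives an 8.5-fold higher number from compound 2 to compound 4 (0.93 log units; beyond the scatter) and shows that compound 2 stands apart from the propyl compound as well as from the butyl one, so among these three compounds the phenoxy-bearing chain matters far more than one methyl on a plain chain. Ethyl in place of phenyl, on the saturated chain carbon bound to that nitrogen, gives an 8.4-fold lower number from compound 1 to compound 4 (0.92 log units; beyond the scatter) and places the propyl compound clear of compound 1, as the butyl compound already was.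

On these data alone, whether a longer plain chain such as hexyl would stay level with butyl and propyl remains open, as does whether an amine or a carboxylic acid in place of phenoxy would keep the number of compound 2. Nothing available here accounts for these differences in growth inhibition.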